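Extending the chain on compound 2: does tolerance rise further?

A few compounds are considered here, and "the series" means these few. Any claim that something is new, unique, unknown or untested is made for them only; others in the source may bear on it.

Of the compounds shown here, two of a shared core have been tested so far. Compound 1 `CCN(c1ccnc(Nc2ccc(C#N)cc2)n1)c1c(F)cc(-c2ccc(C#N)cc2)cc1F` gives 105000 nM in an ADME assay on MT4 cells (Homo sapiens) for cytotoxicity, read by MTT assay, with a stated time of 5 days; a lower number here means that less compound is tolerated, a higher number that more compound is tolerated. Compound 2 `CC(C)CN(c1ccnc(Nc2ccc(C#N)cc2)n1)c1c(F)cc(-c2ccc(C#N)cc2)cc1F` gives 241000 nM in this assay, the highest of the two numbers, and its nearest neighbour is compound 1, a 2.3-fold higher number from compound 1 to compound 2 (0.36 log units; beyond the scatter). That single step is the only one that bears on the next move. Compound 3 `CCC(C)CN(c1ccnc(Nc2ccc(C#N)cc2)n1)c1c(F)cc(-c2ccc(C#N)cc2)cc1F` differs from compound 2 by methyl in place of hydrogen on a saturated chain carbon, three bonds along the chain from a nitrogen on an aromatic ring, again a small growth of the same chain on the nitrogen, one bond further out than before. Since the earlier growth of this chain gave only a modest rise, a similar or smaller move is expected here, towards a higher number or none beyond the scatter. Compound 3 is therefore expected to give 300000 nM, within 150000 nM to 600000 nM, which means a step of a 1.2-fold higher number from compound 2 to compound 3 (0.10 log units; within the scatter) is expected.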

Compound 3, half-maximal cytotoxic concentration: > 255000 nM
Compound 3: no number, only a limit (the forecaster's own chance of this, stated with the estimate: 15%); the middle value does not contradict the limit.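

In this assay, compound 3 gives no exact number, only a limit: the limit of > 255000 nM in this assay, at which 1 of the 3 values shown sits.

Against its closest relative the step reads an at least 1.0-fold higher number from compound 2 to compound 3 (0.02 log units; that floor lies within the scatter), so this added methyl, three bonds along the chain from a nitrogen on an aromatic ring, shows no rise that can be claimed, and nor does it show a fall. Measured from the smallest chain, the change to sec-butyl gives an at least 2.4-fold higher number from compound 1 to compound 3 (0.38 log units; beyond the scatter), so the larger chains of compound 2 and compound 3 both stay more tolerated than compound 1, and none of the three goes against this.

On these data alone, how far compound 3 truly differs from compound 2 remains unknown. Also open, as far as these compounds go, is how a longer chain, or an amine or a hydroxyl group on this chain, would behave in this assay.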